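This account rests on a few compounds, and the source may have more. Where it says the series, first, only, none or still open, it means among the compounds named here.

Three measured analogues share one core. Compound 1 `Ic1ccc(C2CC(c3ccc4c(c3)OCCO4)=NN2c2ccccc2)cc1` gives 3470 nM in a functional assay on WM 266-4 cells (Homo sapiens) for antiproliferative activity, read by MTT assay, with a stated time of 24 h; a higher number here means a weaker inhibitor of growth, a lower number a stronger inhibitor of growth. Compound 2 `Fc1ccccc1C1CC(c2ccc3c(c2)OCCO3)=NN1c1ccccc1` gives 9120 nM in this assay, and compound 3 `Fc1ccc(C2CC(c3ccc4c(c3)OCCO4)=NN2c2ccccc2)cc1` gives 6050 nM in this assay. Compound 2 stands highest of the three numbers: the step of a 2.6-fold higher number from compound 1 to compound 2 (0.42 log units; beyond the scatter) lies beyond the scatter, whereas a 1.5-fold lower number from compound 2 to compound 3 (0.18 log units; within the scatter) and a 1.7-fold higher number from compound 1 to compound 3 (0.24 log units; within the scatter) both stay within it.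

The unmeasured compound 4 `c1ccc(N2N=C(c3ccc4c(c3)OCCO4)CC2c2cccc3ccccc23)cc1` differs from compound 2 in one place: naphthalen-1-yl in place of 2-fluorophenyl on a saturated ring carbon. Going by the values given here, two measured steps bear on this change, since both alter the group on the same saturated ring carbon. The step of a 2.6-fold higher number from compound 1 to compound 2 (0.42 log units; beyond the scatter) was modest and beyond the scatter, and the step of a 1.5-fold lower number from compound 2 to compound 3 (0.18 log units; within the scatter) was within it. Among the compounds with values here, no measured step introduces naphthalen-1-yl, so any expectation rests on these two swaps alone. Taken together, they suggest that the direction from compound 2 is more likely downward than upward, but only by a modest margin. The author therefore expects a step of a 2.3-fold lower number from compound 2 to compound 4 (0.36 log units; beyond the scatter) toward a lower number. Compound 4 is expected to give about 4000 nM in this assay, within a range from 1500 nM to 11000 nM.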

Compound 4, concentration for 50% growth inhibition: > 100000 nM
Compound 4: only a limit was reported; the forecaster's own chance of this, stated with the estimate: 5%; middle value at least 25-fold (1.39 log units) from the limit.
By their numbers in this assay, from the lowest: compounds 1, 3 and 2 (each within the scatter of the next, the first and the last beyond it). At a limit, above all of these: compound 4.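

Until now, the swaps on this saturated ring carbon had involved only substituted phenyl groups, and the largest step among them was modest. Naphthalen-1-yl, with its 2 six-membered aromatic rings of carbon only, is the first group here to produce large steps, and it does so against all three earlier compounds: an at least 10-fold higher number from compound 2 to compound 4 (1.04 log units; beyond the scatter), an at least 16-fold higher number from compound 3 to compound 4 (1.21 log units; beyond the scatter) and an at least 28-fold higher number from compound 1 to compound 4 (1.45 log units; beyond the scatter). So, across these four compounds, this position accepts the iodo- and fluoro-substituted phenyl groups with activity in a measurable range, but that does not extend to naphthalen-1-yl, and the reading for compound 4 in this assay is a limit rather than a number: the limit of > 100000 nM in this assay, at which 1 of the 4 values shown sits.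

The limit leaves open how far compound 4 actually lies from the others, so each of these steps gives only a lower bound on its size. The compounds shown also leave open what a pyridyl or a cyclohexyl group would give on this carbon, and so whether the sharp change belongs to the second aromatic ring of naphthalen-1-yl or to something else about this group.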